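The source may report more compounds than this note shows. Statements on the series, on what has been measured and on what is new or still open speak of the compounds shown alone.

Measured so far:
compound 1 `COc1cc(/C=C/C(=O)c2c(O)cc(O)cc2OC)cc(OC)c1OC` at 28400 nM
compound 2 `COc1cc(OC)c(C(=O)/C=C/c2ccccc2OC)c(OC)c1` at 19800 nM

In a functional assay on A549 cells (Homo sapiens) for inhibition, read by MTT assay, with a stated time of 72 h (on this read-out lower numbers stand for stronger inhibition and higher numbers for weaker inhibition), compound 2 stands within the scatter of compound 1, and the two numbers cannot be separated. Compound 3 `COc1cc(OC)c(C(=O)/C=C/c2ccc(Cl)cc2)c(OC)c1` is still unmeasured. It differs from compound 2 on a double-bonded chain carbon bound to a double-bonded chain carbon (4-chlorophenyl in place of 2-methoxyphenyl on a double-bonded chain carbon bound to a double-bonded chain carbon). Among the compounds with values here, the series holds no measured step for this exchange of 4-chlorophenyl in place of 2-methoxyphenyl. A modest step toward a lower number in this assay is expected (a 1.7-fold lower number from compound 2 to compound 3 (0.22 log units; within the scatter)). For compound 3 the estimated value is 12000 nM (expected range 4000 nM to 35000 nM).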

Compound 3, half-maximal inhibitory concentration: 13300 nM
Beside the measured number, compound 3's estimate is 1.1-fold (0.04 log units) below it; low and high end bracket the measured number.
By their numbers in this assay, from the lowest: compounds 3, 2 and 1 (each within the scatter of the next, the first and the last beyond it).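

On the double-bonded chain carbon bound to a double-bonded chain carbon, this assay shows a 1.5-fold lower number from compound 2 to compound 3 (0.17 log units; within the scatter) for 4-chlorophenyl in place of 2-methoxyphenyl. This position therefore accepts an exchange of the aromatic substituent, including loss of the methoxy oxygen, without a separable shift in the number. No available measurement explains this result. As far as these compounds go, whether an amine or a carboxylic acid at this position would give a number beyond the scatter remains open. The separate contributions of the chlorine and of the methoxy group also remain unresolved.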